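The compounds below may be only part of what the source reports. "The series", "measured", "known", "first", "only" and "open" are said of these compounds alone.

Working notes on the series, read in a functional assay on A549 cells (Homo sapiens) for antiproliferative activity, read by MTT assay; on this read-out lower numbers stand for stronger inhibition and higher numbers for weaker inhibition. Here compound 1 `COc1cc2c(Oc3ccc(NC(=O)Nc4ccccc4C(F)(F)F)cc3)ccnc2cc1OCCCCCCC(=O)NO` gives 5280 nM and compound 2 `COc1cc2c(Oc3ccc(NC(=O)Nc4ccc(C(F)(F)F)cc4Cl)cc3)ccnc2cc1OCCCCCCC(=O)NO` gives 970 nM, the lower of the two numbers so far. Compound 3 `COc1cc2c(Oc3ccc(NC(=O)Nc4ccc(C)cc4C)cc3)ccnc2cc1OCCCCCCC(=O)NO` departs from compound 2 in one place: 2,4-dimethylphenyl in place of 2-chloro-4-(trifluoromethyl)phenyl on an amide-type nitrogen. In words, 2,4-dimethylphenyl stands in place of 2-chloro-4-(trifluoromethyl)phenyl on an amide-type nitrogen. Among the compounds with values here, only one measured step bears on this: a 5.4-fold lower number from compound 1 to compound 2 (0.74 log units; beyond the scatter), a modest change beyond the scatter, made at the same place. Within the data shown here, no measured compound carries 2,4-dimethylphenyl, so the direction rests on this single pair. A move back towards higher numbers is expected, smaller than that step, though it may stay close to the scatter. The expected change is a 2.1-fold higher number from compound 2 to compound 3 (0.31 log units; beyond the scatter). For compound 3 the estimated value is 2000 nM, with an expected range of 700 nM to 6000 nM.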

Compound 3, half-maximal inhibitory concentration: 5490 nM
For compound 3 the middle estimate is 2.7-fold (0.44 log units) below the measured one; low and high end bracket the measured number.
By their numbers in this assay, from the lowest: compound 2; then compounds 1 and 3 (each within the scatter of the next).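

In this assay, the position on the amide-type nitrogen now responds in both directions: replacing 2-chloro-4-(trifluoromethyl)phenyl with 2,4-dimethylphenyl gives a 5.7-fold higher number from compound 2 to compound 3 (0.75 log units; beyond the scatter). Replacing 2-(trifluoromethyl)phenyl with 2,4-dimethylphenyl gives a 1.0-fold higher number from compound 1 to compound 3 (0.02 log units; within the scatter), so among these three groups only the 2-chloro-4-(trifluoromethyl)phenyl of compound 2 stands apart, while compound 1 and compound 3 cannot be told apart. Nothing available explains why the two-substituent 2,4-dimethylphenyl group does not share the lower number of compound 2.

The compounds shown leave open whether the chlorine, the trifluoromethyl group or the two together account for the lower number of compound 2. A 2-chlorophenyl or a 4-(trifluoromethyl)phenyl group on the same nitrogen would separate these contributions, and a 2,4-dichlorophenyl group would test the chlorine further.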